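This account rests on a few compounds, and the source may have more. Where it says the series, first, only, none or still open, it means among the compounds named here.

Values from a functional assay on Vero cells (Chlorocebus sabaeus) for inhibition (a higher number here means a weaker inhibitor, a lower number a stronger inhibitor), follow.

- compound 1 `Nc1nc(O)c2ncn([C@@H]3O[C@@H](CO)C=C3F)c2n1` gives > 100000 nM (a limit)
- compound 2 `Nc1ccn([C@@H]2O[C@@H](CO)C=C2F)c(=O)n1` gives > 100000 nM (a limit)

Neither entry is a number. Among the compounds with values here, compound 1 stands at the limit of > 100000 nM in this assay, at which 2 of the 2 values shown sit, and compound 2 shares that position, so the two cannot be ranked and no measured step is available. Within the data shown here, what is known is only that neither compound reached half-maximal inhibition within the tested range in this assay.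

The next compound is compound 3 `OC[C@H]1C=C(F)[C@H](n2cnc3c(O)ncnc32)O1`, which keeps the rest of compound 1 and carries hydrogen in place of amino on an aromatic carbon, between two ring nitrogen atoms (hydrogen in place of amino on an aromatic carbon). No step beyond the scatter is expected in this assay, and no direction of change can be favoured. This expectation rests on compound 1 , whose > 100000 nM is a limit and offers no activity to build on. The estimated a number no higher from compound 1 to compound 3 (the limit leaves the size open) is therefore expected to be nil. Compound 3 is expected at 100000 nM (estimated range 30000 nM to 300000 nM), most probably reported only as a limit.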

Compound 3, half-maximal inhibitory concentration: > 100000 nM
Compound 3 was reported as a limit (the forecaster's own chance of this, stated with the estimate: 90%); the middle value lies on the limit itself.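

In this assay compound 3 gives > 100000 nM, which is a limit, so no step can be read from compound 1 to compound 3, whose values are both limits: the limit of > 100000 nM in this assay, at which 3 of the 3 values shown sit.

The compounds shown leave open whether hydrogen in place of amino on an aromatic carbon alters inhibition at all, and how far any compound's true value lies from the limit.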